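Working notes on compound 4 and the shared core

The source may report more compounds than this note shows. Statements on the series, on what has been measured and on what is new or still open speak of the compounds shown alone.

Measured so far in a functional assay on HepG2 cells (Homo sapiens) for inhibition, read by MTT assay, with a stated time of 72 h; a lower number here means a stronger inhibitor, a higher number a weaker inhibitor:
compound 1 `O=C(OC1(C(=O)Nc2ccc([N+](=O)[O-])cc2)CCCCC1)c1ccc(C(F)(F)F)cc1` gives 29.1 nM;
compound 2 `O=C(OC1(C(=O)Nc2ccc([N+](=O)[O-])cc2)CCCCC1)c1ccc(Br)cc1` gives 284 nM;
compound 3 `CCOC(=O)c1ccccc1C(=O)OC1(C(=O)Nc2ccc([N+](=O)[O-])cc2)CCCCC1` gives 517 nM.

Of these three numbers, compound 3 and compound 2 lie within the scatter of each other, and compound 1 lies well below both. Compound 4 `O=C(OC1(C(=O)Nc2ccc([N+](=O)[O-])cc2)CCCCC1)c1ccccc1` differs from compound 3 by hydrogen in place of ethoxycarbonyl on an aromatic carbon. Among the measured compounds shown here, no measured step removes a group at this place. For the measured compounds named here, the only step available, a 9.8-fold higher number from compound 1 to compound 2 (0.99 log units; beyond the scatter), shows that exchanging one group for another on that aromatic ring can move the number modestly, but it does not tell what losing the group altogether does. Going by the values given here, with no direct precedent the direction is open, so for compound 4 the expected step is a 1.1-fold lower number from compound 3 to compound 4 (0.06 log units; within the scatter), with a wide range. Compound 4 is estimated at 450 nM, between 90 nM and 2500 nM.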

Compound 4, half-maximal inhibitory concentration: 734 nM
Estimate against measurement, compound 4: 1.6-fold (0.21 log units) below; low and high end bracket the measured number.
By their numbers in this assay, from the lowest: compound 1; then compounds 2, 3 and 4 (each within the scatter of the next, the first and the last beyond it).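

Hydrogen in place of ethoxycarbonyl gives a 1.4-fold higher number from compound 3 to compound 4 (0.15 log units; within the scatter) and so shows that this group, on an aromatic carbon ortho to a large group, can be lost without a change beyond the scatter. Hydrogen in place of bromo gives a 2.6-fold higher number from compound 2 to compound 4 (0.41 log units; beyond the scatter) and hydrogen in place of trifluoromethyl gives a 25-fold higher number from compound 1 to compound 4 (1.40 log units; beyond the scatter) and so the largest gap from hydrogen in this set belongs to trifluoromethyl. Nothing measured here bears on the reason for these steps.

As far as these compounds go, whether an amine or a carboxylic acid on this ring would stay close to hydrogen or approach trifluoromethyl remains open.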